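Exchanging the Sulfonyl Aryl Group in a Small Series

The source may hold more compounds than are shown below. What is called first, only, known or untested is meant among the compounds shown, and "the series" means these compounds.

Of the compounds shown here, two sharing one core have been measured in an assay on isolated protein for displacement of a labelled ligand from metabotropic glutamate receptor 5 (Homo sapiens), with a stated time of 60 min, tested at 1 uM; on this read-out lower numbers stand for less inhibition and higher numbers for more inhibition at the one concentration tested (going by the name of the read-out). Compound 1 `Cc1ccc(S(=O)(=O)c2cnc3cc(Cl)ccc3c2N2CCC(C)CC2)cc1` gives 94% in this assay, the higher of the two numbers. Compound 2 `Cc1cc(C)cc(S(=O)(=O)c2cnc3ccc(C)cc3c2N2CCC(C)CC2)c1` gives 80% in this assay, and the gap between the two lies beyond the usual scatter. Compound 2 differs from compound 1 in more than one place, so the two values are noted side by side without any single change being assigned to the gap.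

Compound 3 `COc1cccc(S(=O)(=O)c2cnc3cc(Cl)ccc3c2N2CCC(C)CC2)c1` has not yet been measured. It differs from compound 1 in one place: 3-methoxyphenyl in place of 4-methylphenyl on a sulfonyl sulfur. Within the data shown here, with no single-change step among the measured compounds, the expected step from compound 1 to compound 3 in this assay, a number 8 percentage points lower from compound 1 to compound 3 (within the scatter), is small and downward, likely within the scatter. Compound 3 is estimated to give 86% in this assay, within a range of 66% to 97%.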

Compound 3, a percentage reported as inhibition, at one concentration (the size of the read-out at that concentration, not a potency): 93%
Compound 3: the middle estimate sits 7 percentage points below what was measured, within the range that was stated.
By their numbers in this assay, from the lowest: compound 2; then compounds 3 and 1 (each within the scatter of the next).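

Among these compounds, the step of a number 1 percentage points lower from compound 1 to compound 3 (within the scatter) in this assay is the first change that can be read at a single place, on a sulfonyl sulfur. It shows that 3-methoxyphenyl, with its oxygen and hydrogen-bond acceptor, can take the place of 4-methylphenyl there without a difference that can be told apart from the scatter at the one concentration tested. No measurement at hand bears on why the two values agree.

The compounds shown carry only carbon-ring aryl groups at this place, so it remains open whether a pyridine ring, or an aryl ring bearing a carboxylic acid or an amine, would leave the read-out unchanged. The single concentration also leaves open whether compound 1 and compound 3 would match in potency.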